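A few compounds are considered here, and "the series" means these few. Any claim that something is new, unique, unknown or untested is made for them only; others in the source may bear on it.

Compound 3 `Cc1nnc(-c2cccc(-c3ccc(C(=O)N(Cc4cccc(OCCCCCC(=O)O)c4)C(C)C)cc3)c2)o1` was tested in an ADME assay on Raji cells (Homo sapiens) for cytotoxicity, read by CellTiter-Glo and resazurin assay, with a stated time of 72 h (a higher number here means that more compound is needed for the effect, a lower number that less compound is needed), where its result is only a limit, > 26000 nM. Compound 1 `CC(=O)Nc1cccc(-c2ccc(C(=O)N(Cc3cccc(OCCCCCC(=O)O)c3)C(C)C)cc2)c1` likewise reaches only a limit in this assay, > 26000 nM. Compound 2 `CC(C)N(Cc1cccc(OCCCCCC(=O)O)c1)C(=O)c1ccc(-c2ccoc2)cc1` also reaches only a limit, > 26000 nM. The three measured steps, a step that the two limits leave unreadable from compound 1 to compound 2, a step that the two limits leave unreadable from compound 1 to compound 3 and a step that the two limits leave unreadable from compound 2 to compound 3, cannot be sized because of the limit of > 26000 nM in this assay, at which 3 of the 3 values shown sit. Compound 4 `CC(C)N(Cc1cccc(OCCCCCC(=O)O)c1)C(=O)c1ccc(-c2ccc3[nH]ccc3c2)cc1` differs from compound 3 in one place: 1H-indol-5-yl in place of 3-(5-methyl-1,3,4-oxadiazol-2-yl)phenyl on an aromatic carbon. Among the compounds with values here, no measured step gives a readable size for such a change, so nothing beyond the usual scatter can be expected in this assay, and compound 4 is expected to sit at the limit as well. The estimate for compound 4 is 30000 nM, with a range from 8000 nM to 120000 nM. The step expected from compound 3 to compound 4 is a step that the limit leaves unreadable from compound 3 to compound 4.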

Compound 4, half-maximal effective concentration: > 26000 nM
Compound 4 ended at the assay's limit; the forecaster's own chance of this, stated with the estimate: 85%; the middle value lies beyond the limit too.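

The steps from compound 1, compound 2 and compound 3 to compound 4 cannot be read, for one shared reason: the limit of > 26000 nM in this assay, at which 4 of the 4 values shown sit. The compounds shown leave open whether changing this group on the shared core affects the result in this assay at all.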